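Nitro for Fluoro on a Benzamide: Expected Cytotoxicity

The source may hold more compounds than are shown below. What is called first, only, known or untested is meant among the compounds shown, and "the series" means these compounds.

Measured compounds in a toxicity assay on THP-1 cells (Homo sapiens) for inhibition; on this read-out lower numbers stand for higher toxicity in this test and higher numbers for lower toxicity in this test:
- Compound 1, `COc1ccc(-c2cnc(NC(=O)c3cccc([N+](=O)[O-])c3)n2C)cc1`, gives > 100000 nM in this assay, which is a limit of the test and not a number.
- Compound 2, `COc1ccc(-c2cnc(NC(=O)c3ccc(F)cc3)n2C)cc1`, gives >= 50000 nM in this assay, also a limit.
- Compound 3, `COc1ccc(-c2cnc(NC(=O)c3cccc(F)c3)n2C)cc1`, gives > 100000 nM in this assay, also a limit.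

Compound 4, `COc1ccc(-c2cnc(NC(=O)c3ccc([N+](=O)[O-])cc3)n2C)cc1`, is not yet measured. Among the measured compounds shown here, all three measured values are limits, so no step among them has a readable size. From compound 3 to compound 1 the change is nitro in place of fluoro on an aromatic carbon, and the step that the two limits leave unreadable from compound 3 to compound 1 stays unreadable because the limit of > 100000 nM in this assay, at which 2 of the 3 values shown sit, holds both of its ends. The cores of compound 2 and compound 3 differ as 4-fluorophenyl in place of 3-fluorophenyl on a carbonyl carbon, and the step that the two limits leave unreadable from compound 2 to compound 3 is likewise unreadable because the limit of >= 50000 nM in this assay, at which 1 of the 3 values shown sits, and the limit of > 100000 nM in this assay, at which 2 of the 3 values shown sit, are each only limits.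

The change from compound 2 to compound 4 is nitro in place of fluoro on an aromatic carbon. It is the same kind of change as from compound 3 to compound 1, not the same: there the place is meta to a large group, here it is para to a large group.

With the earlier step that the two limits leave unreadable from compound 3 to compound 1 unreadable and both of its ends at limits, the step to compound 4 is expected to be a step that the limit leaves unreadable from compound 2 to compound 4. For compound 4 the estimate in this assay is 100000 nM, within 40000 nM to 250000 nM, most likely again reported only as a limit.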

Compound 4, half-maximal cytotoxic concentration: > 100000 nM
Compound 4 was reported as a limit; the forecaster's own chance of this, stated with the estimate: 85%; the middle value sits exactly at the limit.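

In this assay compound 2 and compound 4 are both reported only as limits of the test and not as numbers, so no new step can be read between them. The compounds shown leave open what the true half-maximal cytotoxic concentration of any of the four is, and whether nitro in place of fluoro changes it at all.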